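Benzyl in place of tert-butyl, tried a second time

A few compounds are considered here, and "the series" means these few. Any claim that something is new, unique, unknown or untested is made for them only; others in the source may bear on it.

Compound 1 `CC1=C(C(=O)OC(C)(C)C)C(c2ccsc2)NC(=O)N1` is measured in an assay on membranes from HEK293 cells for displacement of a labelled ligand from adenosine receptor A2b (Homo sapiens), read by scintillation counting, with a stated time of 30 min, tested at 1 uM (a lower number here means less inhibition, a higher number more inhibition at the concentration tested (going by the name of the read-out)), and gives 47%. Compound 2 `CC1=C(C(=O)OCc2ccccc2)C(c2ccsc2)NC(=O)N1` differs from it by benzyl in place of tert-butyl on an oxygen next to a carbonyl group, and in this assay compound 2 gives 44%, so the step of a number 3 percentage points lower from compound 1 to compound 2 (within the scatter) is a small one.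

Compound 3 `CC1=C(C(=O)OC(C)(C)C)C(c2cccs2)NC(=S)N1` has a different core; how its core differs from that of compound 1 is not broken down here. In this assay compound 3 gives 26%.

Compound 4 `CC1=C(C(=O)OCc2ccccc2)C(c2cccs2)NC(=S)N1` has not been measured. It differs from compound 3 by benzyl in place of tert-butyl on an oxygen next to a carbonyl group, the same change as that from compound 1 to compound 2, at the same place.

The step is expected to be a number 2 percentage points lower from compound 3 to compound 4 (within the scatter). That expectation rests on the earlier matching change, which gave a number 3 percentage points lower from compound 1 to compound 2 (within the scatter). Compound 4 is therefore expected to give about 24%, most likely between 12% and 36%.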

Compound 4, a percentage reported as inhibition, at one concentration (the size of the read-out at that concentration, not a potency): 45%
Compound 4: middle estimate off by 21 percentage points, on the low side; the measured number lies above the stated range.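

In this assay, benzyl in place of tert-butyl on an oxygen next to a carbonyl group gives a number 19 percentage points higher from compound 3 to compound 4 (beyond the scatter), so a result from one core did not predict the result on the other. The two steps differ: the same change on two cores in this assay, a number 3 percentage points lower (within the scatter) from compound 1 to compound 2 and a number 19 percentage points higher (beyond the scatter) from compound 3 to compound 4, 22 percentage points apart, beyond the scatter of two such steps. This shows that, for these two pairs, the outcome of the change depends on the core that carries it, but it does not show which part of the core is responsible or what a third core would do.

The compounds shown leave open what other groups would do on that oxygen, such as methyl or a longer chain. They also leave open whether a carboxylic acid or an amide at this place would follow either pair.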